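Swapping Methyl for Cyclopropyl on an Azido Nucleoside

This account rests on a few compounds, and the source may have more. Where it says the series, first, only, none or still open, it means among the compounds named here.

Compound 1 `CNc1nc(Cl)nc2c1ncn2[C@H]1C[C@H](N=[N+]=[N-])[C@@H](CO)O1` was tested in an ADME assay on CCRF-CEM cells (Homo sapiens) for cytotoxicity, with a stated time of 5 days (on this read-out higher numbers stand for weaker inhibition and lower numbers for stronger inhibition), for its effect on leukaemia cells. In this assay compound 1 gives only a limit, > 100000 nM rather than a number. Compound 2 `CC(C)(CO)Nc1nc(N)nc2c1ncn2[C@H]1C[C@H](N=[N+]=[N-])[C@@H](CO)O1` also gives only a limit in this assay, namely > 100000 nM as well. Compound 3 `[N-]=[N+]=N[C@H]1C[C@H](n2cnc3c(Cl)nc(F)nc32)O[C@@H]1CO` gives a measured number in this assay, 13300 nM in all. Compound 1 therefore sits at the limit of > 100000 nM in this assay, at which 2 of the 3 values shown sit, and cannot be ranked against compound 3. Compound 4 `[N-]=[N+]=N[C@H]1C[C@H](n2cnc3c(NC4CC4)nc(Cl)nc32)O[C@@H]1CO` differs from compound 1 in one place: cyclopropyl in place of methyl on a nitrogen on an aromatic ring is the whole change. Among the measured compounds shown here, no measured pair shows what such a change does, so the step expected here is an at least 1.2-fold lower number from compound 1 to compound 4 (0.09 log units; that floor lies within the scatter) at most, within the scatter. Compound 4 is expected to give 80000 nM with a range from 20000 nM to 300000 nM in this assay.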

Compound 4, half-maximal inhibitory concentration: > 100000 nM
Compound 4: a limit, no number; the forecaster's own chance of this, stated with the estimate: 55%; at least 1.2-fold (0.09 log units) between middle value and limit.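

In this assay, compound 1 and compound 4 each give only a limit, not a number, so no step between them can be read: the limit of > 100000 nM in this assay, at which 3 of the 4 values shown sit.

On these data alone, whether cyclopropyl in place of methyl on that nitrogen changes the effect on these cells at all remains open.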